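This account rests on a few compounds, and the source may have more. Where it says the series, first, only, none or still open, it means among the compounds named here.

Measured compounds:
compound 1 `COc1ccccc1CNC(=O)Nc1nn(-c2ccccc2)c(=O)c2ccccc12` — 28%
compound 2 `O=C(Nc1nn(-c2ccccc2)c(=O)c2ccccc12)c1ccco1` — 23%

In an assay on CHO cells for displacement of a labelled ligand from adenosine receptor A1 (Homo sapiens), tested at 10 uM (a lower number here means less inhibition, a higher number more inhibition at the concentration tested (going by the name of the read-out)), compound 1 gives 28%. Compound 2 gives 23%, the step being a number 5 percentage points lower from compound 1 to compound 2 (within the scatter), so the two numbers sit within the scatter of each other and compound 1 cannot be singled out.

Compound 3 `COc1ccc(NC(=O)Nc2nn(-c3ccccc3)c(=O)c3ccccc23)c(OC)c1` differs from compound 1 by 2,4-dimethoxyphenyl in place of 2-methoxybenzyl on an amide-type nitrogen. Among the compounds with values here, no measured step touches the amide nitrogen; the one step known, a number 5 percentage points lower from compound 1 to compound 2 (within the scatter), alters the carbonyl carbon instead, so it bears only loosely on this change. With both measured numbers close together, no shift beyond the scatter is expected.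

For compound 3 the expected step is a number 3 percentage points lower from compound 1 to compound 3 (within the scatter). The estimate for compound 3 in this assay is 25%, ranging from 8% to 45%.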

Compound 3, a percentage reported as inhibition, at one concentration (the size of the read-out at that concentration, not a potency): 29%
Estimate against measurement, compound 3: 4 percentage points below; the range from low to high includes it.
By their numbers in this assay, from the lowest: compounds 2, 1 and 3 (each within the scatter of the next).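

Within the data shown here, at this place, on an amide-type nitrogen, the change to 2,4-dimethoxyphenyl gives a number 1 percentage points higher from compound 1 to compound 3 (within the scatter) in this assay and is the first reading of this position. The one-atom-larger group with its added methoxy therefore leaves the inhibition within the scatter, so the two aryl-bearing ureas cannot be told apart here. No supporting data bear on this result.

On these data alone, whether an aminoethyl chain or a carboxylic acid on this nitrogen would move the number beyond the scatter stays open. Also open, as far as these compounds go, is whether a simple unsubstituted phenyl would read any differently.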